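Lengthening the ester chain on the core of compound 3

A few compounds are considered here, and "the series" means these few. Any claim that something is new, unique, unknown or untested is made for them only; others in the source may bear on it.

In a functional assay on MCF7 cells (Homo sapiens) for cytotoxicity, read by neutral red uptake, with a stated time of 3 days (a lower number here means a stronger inhibitor, a higher number a weaker inhibitor), compound 3 `CCC(=O)OCc1c(F)c(N)c2c(=O)cc(-c3ccc(N)c(F)c3)oc2c1F` gives 130 nM, the lowest of the two numbers shown. Compound 2 `Nc1ccc(-c2cc(=O)c3c(N)c(F)c(Cl)c(F)c3o2)cc1F` gives 210 nM, the difference being a 1.6-fold lower number from compound 2 to compound 3 (0.21 log units; within the scatter). Compound 1 `Nc1ccc(-c2cc(=O)c3c(N)c(F)c(O)c(F)c3o2)cc1F` reports only > 10000 nM, a limit of the assay rather than a number (the limit of > 10000 nM in this assay, at which 1 of the 3 values shown sits). From that limit the changes at the hydroxy position are large: an at least 47-fold lower number from compound 1 to compound 2 (1.67 log units; beyond the scatter) and an at least 76-fold lower number from compound 1 to compound 3 (1.88 log units; beyond the scatter). Compound 4 `CCCCCCCCCC(=O)OCc1c(F)c(N)c2c(=O)cc(-c3ccc(N)c(F)c3)oc2c1F` differs from compound 3 by heptyl in place of hydrogen on a saturated chain carbon, two bonds along the chain from a carbonyl carbon. Within the data shown here, no measured step alters this chain; the only step that touches the ester, a 1.6-fold lower number from compound 2 to compound 3 (0.21 log units; within the scatter), is within the scatter, so no step beyond the scatter is expected in this assay. Compound 4 is therefore expected at 150 nM, with a range from 40 nM to 600 nM. The expected step is a 1.2-fold higher number from compound 3 to compound 4 (0.06 log units; within the scatter).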

Compound 4, half-maximal inhibitory concentration: 100 nM
Compound 4: middle estimate off by 1.5-fold (0.18 log units), on the high side; the measured number falls inside the stated range.
By their numbers in this assay, from the lowest: compounds 4, 3 and 2 (each within the scatter of the next, the first and the last beyond it). At a limit, above all of these: compound 1.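

In this assay, heptyl in place of hydrogen on a saturated chain carbon, two bonds along the chain from a carbonyl carbon, gives a 1.3-fold lower number from compound 3 to compound 4 (0.11 log units; within the scatter). Among these compounds, compound 3 and compound 4 therefore read alike, the first evidence that this chain carbon accepts heptyl without a step beyond the scatter. No measurement shown gives a cause for this step.

Still open, on these data alone, is how a carboxylic acid or an amine in place of heptyl would read in this assay. A longer chain also remains to be placed against compound 4.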